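Hydroxamate chain length in the shared core series

This account rests on a few compounds, and the source may have more. Where it says the series, first, only, none or still open, it means among the compounds named here.

Compound 1 `CNC(=O)CCCCCCCn1nc(-c2ccc3oc(N)nc3c2)c2c(N)ncnc21` in a functional assay on HepG2 cells (Homo sapiens) for inhibition, read by MTT assay, with a stated time of 72 h (on this read-out higher numbers stand for weaker inhibition and lower numbers for stronger inhibition), gives 3640 nM.
Compound 2 `Nc1nc2cc(-c3nn(CCCCCC(=O)NO)c4ncnc(N)c34)ccc2o1` in this assay gives 1990 nM.
Compound 3 `Nc1nc2cc(-c3nn(CCCCCCCCCC(=O)NO)c4ncnc(N)c34)ccc2o1` in this assay gives 28600 nM.

Compound 2 holds the lowest of the three numbers; compound 1 sits within the scatter of it, while compound 3 lies clearly beyond. Compound 4 `Nc1nc2cc(-c3nn(CC(=O)NO)c4ncnc(N)c34)ccc2o1` differs from compound 2 by hydroxycarbamoyl in place of 4-(hydroxycarbamoyl)butyl on a saturated chain carbon bound to an aromatic nitrogen. Among the measured compounds shown here, no measured step shortens this chain; the only step that alters its length runs the other way, a 14-fold higher number from compound 2 to compound 3 (1.16 log units; beyond the scatter), and a 7.9-fold higher number from compound 1 to compound 3 (0.90 log units; beyond the scatter) points the same way. Chain length thus matters in this assay, and as a working expectation a departure from compound 2 in either direction is assumed to cost potency. For compound 4 a modest rise in the number is expected, a 3.0-fold higher number from compound 2 to compound 4 (0.48 log units; beyond the scatter). Compound 4 is estimated at 6000 nM, within 1500 nM to 30000 nM.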

Compound 4, half-maximal inhibitory concentration: > 150000 nM
Compound 4 ended at the assay's limit; the forecaster's own chance of this, stated with the estimate: 5%; middle value at least 25-fold (1.39 log units) from the limit.
By their numbers in this assay, from the lowest: compounds 2 and 1 (each within the scatter of the next); then compound 3. At a limit, above all of these: compound 4.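

Compound 4 ends at a limit of the read-out, not at a number: the limit of > 150000 nM in this assay, at which 1 of the 4 values shown sits. Among the compounds shown here, this is the first shortening of the chain, with an at least 75-fold higher number from compound 2 to compound 4 (1.87 log units; beyond the scatter) and an at least 41-fold higher number from compound 1 to compound 4 (1.61 log units; beyond the scatter). On a saturated chain carbon bound to an aromatic nitrogen, both shortening and lengthening the chain of compound 2 now raise the number beyond the scatter.

Chains of intermediate length on either side of compound 2 remain open, so the best length is not fixed. Also open, from the compounds shown here alone, is whether a carboxylic acid or an amine in place of the hydroxycarbamoyl end would follow the same trend with chain length.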